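Morpholine for pyrrolidine on a thiosemicarbazone core

This account rests on a few compounds, and the source may have more. Where it says the series, first, only, none or still open, it means among the compounds named here.

Measured compounds:
compound 1 `Cc1ccnc(/C(N)=N/NC(=S)N2CCCC2)c1` — 63.6%
compound 2 `N/C(=N\NC(=S)N1CCOCC1)c1ccc(F)cn1` — 39.5%
compound 3 `N/C(=N\NC(=S)N1CCN(c2ccccn2)CC1)c1ccc(F)cn1` — 35.8%

In a functional assay on MCF7 cells (Homo sapiens) for cytotoxicity, read by MTT assay, with a stated time of 72 h, tested at 10 uM (a higher number here means more inhibition of growth at the concentration tested, a lower number less inhibition of growth), compound 1 gives 63.6%, the highest of the three numbers; compound 2 gives 39.5% and compound 3 gives 35.8%, both beyond the scatter below compound 1. Compound 4 `Cc1ccnc(/C(N)=N/NC(=S)N2CCOCC2)c1` is not yet measured. It differs from compound 1 in one place: morpholin-4-yl in place of pyrrolidin-1-yl on a thiocarbonyl carbon. Within the data shown here, no measured pair isolates this change, since compound 2 and compound 3 carry a different pyridine. Among the measured compounds shown here, the morpholin-4-yl compounds measured so far sit lower, so a moderate fall is expected in this assay, as a number 13.6 percentage points lower from compound 1 to compound 4 (beyond the scatter). Compound 4 is thus estimated at 50%, with a range from 32% to 68%.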

Compound 4, percent growth inhibition at one concentration: 6.86%
Estimate against measurement, compound 4: 43.1 percentage points above, and the stated range ends above it.
By their numbers in this assay, from the lowest: compound 4; then compounds 3 and 2 (each within the scatter of the next); then compound 1.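

In this assay, among these compounds, morpholin-4-yl in place of pyrrolidin-1-yl on a thiocarbonyl carbon, with the rest of the structure unchanged, gives a number 56.7 percentage points lower from compound 1 to compound 4 (beyond the scatter) as the first reading of this change in isolation. The position is therefore highly sensitive to which of these two rings it carries. Nothing available explains the fall. The compounds shown leave open whether piperidin-1-yl, a six-membered ring without the oxygen, would stay near compound 1 or fall towards compound 4. They also leave open whether an open-chain dimethylamino group would be tolerated here.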